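Swapping Bromo for Methyl: Expected Cytotoxicity of Compound 4

This account rests on a few compounds, and the source may have more. Where it says the series, first, only, none or still open, it means among the compounds named here.

Compound 1 `Fc1ccc(C2CC(c3ccc(Cl)s3)=NN2c2nc(-c3ccc(Br)cc3)cs2)cc1` gives > 500 ug/mL in an ADME assay on NIH3T3 cells (Mus musculus) for cytotoxicity, read by XTT assay, with a stated time of 24 h (on this read-out lower numbers stand for stronger inhibition and higher numbers for weaker inhibition), a limit of the assay rather than a number.
Compound 2 `Cc1ccc(C2=NN(c3nc(-c4ccc(Cl)cc4)cs3)C(c3ccc(F)cc3)C2)s1` gives > 500 ug/mL in this assay, again only a limit.
Compound 3 `Cc1ccc(C2=NN(c3nc(-c4ccc([N+](=O)[O-])cc4)cs3)C(c3ccc(F)cc3)C2)s1` gives 15.6 ug/mL in this assay.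

Compound 1 therefore stands at the limit of > 500 ug/mL in this assay, at which 2 of the 3 values shown sit, with no number of its own. Compound 4 `Cc1ccc(-c2csc(N3N=C(c4ccc(Cl)s4)CC3c3ccc(F)cc3)n2)cc1` differs from it by methyl in place of bromo on an aromatic carbon. Among the measured compounds shown here, the only measured step, an at least 32-fold lower number from compound 2 to compound 3 (1.50 log units; beyond the scatter), concerns a different change and so says little about this one. Nothing measured points toward a change beyond the scatter, so the expected step of a number no higher from compound 1 to compound 4 (the limit leaves the size open) is small. Compound 4 is estimated at 500 ug/mL, between 150 ug/mL and 1500 ug/mL, most likely reported once more as a limit.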

Compound 4, half-maximal inhibitory concentration: > 500 ug/mL
Compound 4 was reported as a limit (the forecaster's own chance of this, stated with the estimate: 75%); the middle value sits exactly at the limit.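

Among the compounds shown here, compound 1 and compound 4 are both reported only as limits, so no step between them can be read: the limit of > 500 ug/mL in this assay, at which 3 of the 4 values shown sit.

On these data alone, whether methyl in place of bromo changes the result in this assay stays open.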